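The compounds below may be only part of what the source reports. "The series", "measured", "known", "first", "only" and "open" are said of these compounds alone.

Measured so far in a functional assay on L1210 cells (Mus musculus) for inhibition; a higher number here means a weaker inhibitor, a lower number a stronger inhibitor:

- compound 1 `C#CCN(Cc1ccc2nc(C)nc(O)c2c1)c1cccc(C)c1` gives > 5000 nM (a limit)
- compound 2 `C#CCN(Cc1ccc2nc(C)nc(O)c2c1)c1cccc(C(C)O)c1` gives > 49000 nM (a limit)
- compound 3 `C#CCN(Cc1ccc2nc(C)nc(O)c2c1)c1cccc(Br)c1` gives 1800 nM (a number)

Compound 3 is the only one of the three with a number rather than a limit, so it is the single firm reference point in this assay for this series.

Compound 4 `C#CCN(Cc1ccc2nc(C)nc(O)c2c1)c1cccc(I)c1` differs from compound 3 by iodo in place of bromo on an aromatic carbon and the change is iodo in place of bromo on an aromatic carbon, meta to a large group.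

Going by the values given here, two measured steps bear on this change, both bringing in bromo: an at least 2.7-fold lower number from compound 1 to compound 3 (0.44 log units; beyond the scatter) (bromo in place of methyl) and an at least 27-fold lower number from compound 2 to compound 3 (1.43 log units; beyond the scatter) (bromo in place of 1-hydroxyethyl). Both rest on limits, and they show that the group at this place can move the number by a modest to large amount. The remaining step, a step that the two limits leave unreadable from compound 1 to compound 2, adds nothing here. Among the compounds with values here, no measured step exchanges bromo for iodo, so the size of the new step has no direct precedent. A slightly lower number is the most that can be expected, with no step beyond the scatter.

The expected outcome is a 1.2-fold lower number from compound 3 to compound 4 (0.08 log units; within the scatter) and no more than that is estimated.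

For compound 4 the estimated value is 1500 nM with an expected range from 600 nM to 4000 nM in this series.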

Compound 4, half-maximal inhibitory concentration: > 5300 nM
Compound 4 was reported as a limit; the forecaster's own chance of this, stated with the estimate: 10%; at least 3.5-fold (0.54 log units) between middle value and limit.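

In this assay, iodo in place of bromo on the aromatic carbon is not a neutral exchange: the change gives an at least 2.9-fold higher number from compound 3 to compound 4 (0.46 log units; beyond the scatter). The earlier steps shown here set bromo apart only from methyl and 1-hydroxyethyl; this one sets it apart from iodo as well, so compound 3 remains the only one of the four with a number rather than a limit, and the steps from compound 1 and from compound 2 to compound 4 cannot be read, with limits at both ends. Compound 4 is itself reported only as a limit, and that limit is not shared with any other compound here: the limit of > 5300 nM in this assay, at which 1 of the 4 values shown sits.

As far as these compounds go, how far compound 4 lies past its limit stays open, and so does any order among compound 1, compound 2 and compound 4. Also open, from the compounds shown here alone, is whether bromo is a narrow optimum at this place, which chloro, fluoro, an amine or a carboxylic acid on the same aromatic carbon would help to settle.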